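A Bromine Swap at the Aryl Position

The source may hold more compounds than are shown below. What is called first, only, known or untested is meant among the compounds shown, and "the series" means these compounds.

In a functional assay on A549 cells (Homo sapiens) for antiproliferative activity, read by MTT assay, with a stated time of 96 h (a higher number here means a weaker inhibitor, a lower number a stronger inhibitor), compound 1 (`CCOC(=O)/C=C1/SC(N2N=C(c3cc4ccccc4o3)CC2c2ccc(Cl)cc2)=NC1=O`) gives > 5 ug/mL. This is a limit of the assay and not a number, so compound 1 has no exact standing. Compound 2 (`CCOC(=O)/C=C1/SC(N2N=C(c3cc4ccccc4o3)CC2c2ccc(OC)c(OC)c2)=NC1=O`) gives 3.42 ug/mL in this assay. Among the measured compounds shown here, only one measured step bears on the question. With 3,4-dimethoxyphenyl in place of 4-chlorophenyl on a saturated ring carbon, the numbers show an at least 1.4-fold lower number from compound 1 to compound 2 (0.16 log units; that floor lies within the scatter). Compound 3 (`CCOC(=O)/C=C1/SC(N2N=C(c3cc4ccccc4o3)CC2c2cccc(Br)c2)=NC1=O`) changes that same place on the shared core, with 3-bromophenyl in place of 4-chlorophenyl on a saturated ring carbon. For the measured compounds named here, the entering group is not the one in compound 2, so that step is only a loose guide, and it starts from a limit. Given an at least 1.4-fold lower number from compound 1 to compound 2 (0.16 log units; that floor lies within the scatter), no step beyond the scatter is expected in this assay, and any shift would most likely be toward a lower number. The step expected here is an at least 1.1-fold lower number from compound 1 to compound 3 (0.04 log units; that floor lies within the scatter). A result reported only as a limit would also be unsurprising. For compound 3 the estimated value is 4.5 ug/mL, with an expected range of 2 ug/mL to 10 ug/mL.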

Compound 3, half-maximal inhibitory concentration: > 5 ug/mL
Compound 3: only a limit was reported; the forecaster's own chance of this, stated with the estimate: 45%; at least 1.1-fold (0.04 log units) between middle value and limit.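

In this assay compound 3, which carries 3-bromophenyl on the saturated ring carbon, gives > 5 ug/mL, a limit of the assay and not a number. Measured against the 3,4-dimethoxyphenyl group, this change gives an at least 1.4-fold higher number from compound 2 to compound 3 (0.16 log units; that floor lies within the scatter), so even this comparison does not establish a real difference at this position. The two halogen-bearing phenyl compounds, compound 1 and compound 3, cannot be compared with each other because both rest on the same limit: the limit of > 5 ug/mL in this assay, at which 2 of the 3 values shown sit.

On these data alone, how far compound 1 and compound 3 lie beyond that limit remains open, and so does the true size of any gap between either of them and compound 2. Also open, as far as these compounds go, is how this position would respond if the aryl ring gave way to a group of another kind, such as an amine, a carboxylic acid or a longer alkyl chain.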